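This account rests on a few compounds, and the source may have more. Where it says the series, first, only, none or still open, it means among the compounds named here.

Working notes on the series, read in an ADME assay (liver) for metabolic stability, with Liver microsome (Rattus norvegicus) as the target, using microsomes and NADPH, with a stated time of 30 min, tested at 1 uM; on this read-out higher numbers stand for fast clearance and lower numbers for slow clearance. Going by the values given here, compound 1 `COCC#Cc1cc(C(O)(C(F)(F)F)C(F)(F)F)cnc1N1CCN(S(=O)(=O)c2ccc(N)nc2)CC1` gives 399 mL.min-1.g-1, and compound 2 `CS(=O)(=O)c1ccc(-c2cc(C(O)(C(F)(F)F)C(F)(F)F)cnc2N2CCN(S(=O)(=O)c3ccc(N)nc3)CC2)cc1` gives 103 mL.min-1.g-1, the lower of the two numbers so far. The next structure is compound 3 `COc1ccc(-c2cc(C(O)(C(F)(F)F)C(F)(F)F)cnc2N2CCN(S(=O)(=O)c3ccc(N)nc3)CC2)cn1`, and the change is 6-methoxypyridin-3-yl in place of 4-(methylsulfonyl)phenyl on an aromatic carbon. In words, 6-methoxypyridin-3-yl takes the place of 4-(methylsulfonyl)phenyl on an aromatic carbon, and the rest of the structure stays the same.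

Among the compounds with values here, only one measured step bears on this, and it involves the same aromatic carbon: a 3.9-fold lower number from compound 1 to compound 2 (0.59 log units; beyond the scatter). That step brought in the group now leaving, and it shows that a change at this carbon can move the number beyond the scatter. Within the data shown here, no measured compound carries 6-methoxypyridin-3-yl, so the evidence for direction is thin. With compound 2 at the low end at 103 mL.min-1.g-1, a rise in this assay smaller than the measured step is expected. The expected change is a 2.1-fold higher number from compound 2 to compound 3 (0.33 log units; beyond the scatter). For compound 3 the estimated value is 220 mL.min-1.g-1, with an expected range of 90 mL.min-1.g-1 to 480 mL.min-1.g-1.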

Compound 3, intrinsic clearance in microsomes: 265 mL.min-1.g-1
Beside the measured number, compound 3's estimate is 1.2-fold (0.08 log units) below it; the range from low to high includes it.
By their numbers in this assay, from the lowest: compound 2; then compounds 3 and 1 (each within the scatter of the next).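

In this assay this aromatic carbon now gives a second step beyond the scatter (a 2.6-fold higher number from compound 2 to compound 3 (0.41 log units; beyond the scatter)), so the number responds to an exchange of one six-membered aromatic ring for another, and not only to the exchange of 3-methoxyprop-1-yn-1-yl for a ring. Going by these compounds alone, the comparison with the first group at this carbon (a 1.5-fold lower number from compound 1 to compound 3 (0.18 log units; within the scatter)) does not separate 6-methoxypyridin-3-yl from 3-methoxyprop-1-yn-1-yl, and only 4-(methylsulfonyl)phenyl stands apart, with steps to both others beyond the scatter, so an aromatic ring at this carbon is not enough on its own to give a number like that of compound 2. Nothing available here explains these differences.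

The step from compound 2 to compound 3 changes the ring and its substituent together, so the compounds shown do not tell whether the methylsulfonyl group or the carbon-only ring goes with the low number. Going by these compounds, how a 4-methoxyphenyl group, or a phenyl ring carrying an amine or a carboxylic acid, would read at this carbon stays open, as does any change elsewhere on the shared core.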